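The compounds below may be only part of what the source reports. "The series", "measured", "known", "first", "only" and "open" are said of these compounds alone.

Compound 1 `C#CCOc1ccc(-c2cc(-c3ccc(OCC#C)cc3)nc(C)n2)cc1`, compound 2 `C#CCOc1ccc(-c2cc(-c3ccc(OCC#C)cc3)nc(N)n2)cc1` and compound 3 `C#CCOc1ccc(-c2cc(-c3cccc(OCC#C)c3)nc(N)n2)cc1` were each tested in an assay on BTI-TN-5B1-4 cells for inhibition of Amine oxidase [flavin-containing] A (Homo sapiens), read by fluorescence and Amplex Red, using microsomes, with a stated time of 30 min; a higher number here means a weaker inhibitor, a lower number a stronger inhibitor. In this assay compound 1 gives 34200 nM, compound 2 gives 32100 nM, and compound 3 gives 24100 nM; the three numbers lie within the scatter of one another. The change methyl in place of amino on an aromatic carbon made a 1.1-fold higher number from compound 2 to compound 1 (0.03 log units; within the scatter). The difference between the cores of compound 2 and compound 3 is not broken down here. Compound 4 `C#CCOc1ccc(-c2cc(-c3cccc(OCC#C)c3)nc(C)n2)cc1` has not yet been measured; it arises from compound 3 by the same change, (methyl in place of amino on an aromatic carbon). Because a 1.1-fold higher number from compound 2 to compound 1 (0.03 log units; within the scatter) stayed within the scatter, a step of about the same size is expected for compound 4, namely a 1.1-fold higher number from compound 3 to compound 4 (0.03 log units; within the scatter). In this assay the estimate for compound 4 is 26000 nM, expected to fall between 12000 nM and 55000 nM.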

Compound 4, half-maximal inhibitory concentration: 21100 nM
Compound 4: the middle estimate sits 1.2-fold (0.09 log units) above what was measured, and the stated range covers the measured number.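

Replacing amino with methyl on the core of compound 3 gives a 1.1-fold lower number from compound 3 to compound 4 (0.06 log units; within the scatter) in this assay, so the change again makes no clear difference to the number. The two steps agree when set side by side: the same change on two cores in this assay, a 1.1-fold higher number (0.03 log units; within the scatter) from compound 2 to compound 1 and a 1.1-fold lower number (0.06 log units; within the scatter) from compound 3 to compound 4, 1.2-fold (0.09 log units) apart, within the scatter of two such steps. This shows that the lack of a clear effect carried over between these two cores, but it does not show that a change with a clear effect would carry over in the same way, and two cores cannot speak for the whole series.

Going by these compounds, only amino and methyl appear at this place, so the result of a carboxylic acid or a longer chain there remains open. On these data alone, whether the same swap behaves alike on any other core also remains open.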